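From allyl to 3-methylbut-2-en-1-yl on the amine

The source may report more compounds than this note shows. Statements on the series, on what has been measured and on what is new or still open speak of the compounds shown alone.

In a functional assay on CEM-SS cells (Homo sapiens) for inhibition, read by thymidine incorporation (on this read-out lower numbers stand for higher toxicity in this test and higher numbers for lower toxicity in this test), compound 3 (`C=CCN(C)C(C)Cn1c(S)nc2ccccc21`) gives > 100000 nM as a limit and not a number. Compound 3 stands at the limit of > 100000 nM in this assay, at which 1 of the 3 values shown sits, and has no exact place in the series.

Compound 1 (`CC(C)=CCNC(C)Cn1c(S)nc2ccccc21`) gives 81000 nM in the same test, and compound 2 (`CC(Cn1c(S)nc2ccccc21)N(C)Cc1ccccc1`) gives 79000 nM there; these two values lie within the scatter of each other.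

Compound 4 (`CC(C)=CCN(C)C(C)Cn1c(S)nc2ccccc21`) comes from compound 3 by one change, 2-methylprop-1-en-1-yl in place of vinyl on a saturated chain carbon bound to an amine nitrogen and in words 2-methylprop-1-en-1-yl in place of vinyl on a saturated chain carbon bound to an amine nitrogen.

Among the measured compounds shown here, two measured steps bear on this change. Compound 1 carries the 3-methylbut-2-en-1-yl group that enters here, and an at least 1.2-fold higher number from compound 1 to compound 3 (0.09 log units; that floor lies within the scatter) is a floor within the scatter. At the place of the change, vinyl in place of phenyl gives an at least 1.2-fold higher number from compound 2 to compound 3 (0.10 log units; that floor lies within the scatter) as a floor that also lies within the scatter.

Neither step shows a size beyond the scatter, so no step beyond it is expected in this assay for this change. The expected step is an at least 1.1-fold lower number from compound 3 to compound 4 (0.07 log units; that floor lies within the scatter) and it stays within the scatter.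

The estimate puts compound 4 at 85000 nM in a range of 45000 nM to 140000 nM as expected from these steps.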

Compound 4, half-maximal cytotoxic concentration: > 100000 nM
Compound 4: no number, only a limit; the forecaster's own chance of this, stated with the estimate: 40%; at least 1.1-fold (0.07 log units) between middle value and limit.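

In this assay compound 4 gives only a limit, as compound 3 does, so the change from vinyl to 2-methylprop-1-en-1-yl, which reads one bond further out as allyl to 3-methylbut-2-en-1-yl, yields no readable step and leaves both compounds without an exact place in the series: the limit of > 100000 nM in this assay, at which 2 of the 4 values shown sit.

The earlier compounds shown here did not show methyl in place of hydrogen on the amine nitrogen with the 3-methylbut-2-en-1-yl group held constant, and this change gives an at least 1.2-fold higher number from compound 1 to compound 4 (0.09 log units; that floor lies within the scatter). At the place of the change, 2-methylprop-1-en-1-yl in place of phenyl gives an at least 1.2-fold higher number from compound 2 to compound 4 (0.10 log units; that floor lies within the scatter), so this floor, like the one for vinyl in place of phenyl, stays within the scatter.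

From the compounds shown here alone, the true sizes of these steps remain open, since each is only a floor set by a limit, and so does the order of compound 3 and compound 4. Also open, going by these compounds, is whether a longer chain or a carboxylic acid on the saturated chain carbon bound to an amine nitrogen would give a number clearly lower or a measured value in place of a limit.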